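The source may report more compounds than this note shows. Statements on the series, on what has been measured and on what is new or still open speak of the compounds shown alone.

Measured so far:
- compound 1, `CCCCCCCCCCCCCC(=O)OC(COP(=O)(O)OP(=O)(O)OC[C@H]1OC(n2ccc(N)nc2=O)[C@@H](O)[C@@H]1O)CSCCCCCCCCCCCC`: > 68000000 nM
- compound 2, `CCCCCCCCCCCCCCCCSCC(COP(=O)(O)OP(=O)(O)OC[C@H]1OC(n2ccc(N)nc2=O)[C@@H](O)[C@@H]1O)OC(=O)CCCCCCCCCCC`: > 64000000 nM

In an ADME assay for solubility (on this read-out lower numbers stand for lower solubility and higher numbers for higher solubility), compound 1 sits at a limit of the assay, not a number, (the limit of > 68000000 nM in this assay, at which 1 of the 2 values shown sits). Compound 2 in this assay likewise sits at a limit, (the limit of > 64000000 nM in this assay, at which 1 of the 2 values shown sits). Within the data shown here, compound 2 therefore stands only as a limit, and no step between the two measured compounds can be counted.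

Compound 3, `CCCCCCCCCCCCCCCCSCC(COP(=O)(O)OP(=O)(O)OC[C@H]1OC(n2ccc(N)nc2=O)[C@@H](O)[C@@H]1O)OC(=O)CCCCCCCCCCCCC`, differs from compound 2 by ethyl in place of hydrogen on a saturated chain carbon, ten or more bonds along the chain from a carbonyl carbon. No step beyond the scatter is expected, an at least 1.0-fold lower number from compound 2 to compound 3 (0.02 log units; that floor lies within the scatter). Compound 3 is expected at about 60000000 nM in this assay, within 20000000 nM to 70000000 nM, most likely reported again as a limit.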

Compound 3, solubility: > 53000000 nM
Compound 3 was reported as a limit; the forecaster's own chance of this, stated with the estimate: 70%; the middle value lies beyond the limit too.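

In this assay compound 3 gives > 53000000 nM, a limit and not a number. Among these compounds, compound 1 and compound 2 also stand only as limits, and no step from either to compound 3 can be read. Going by these compounds, the actual values behind all three limits stay open, and with them any effect of the chain changes.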